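Trading an Acetyl for a Sulfonyl on the Amine

This account rests on a few compounds, and the source may have more. Where it says the series, first, only, none or still open, it means among the compounds named here.

The set has three measured compounds. Compound 1 `CC(=O)N(Cc1cn(Cc2cccc(F)c2F)nn1)Cc1cn(S(=O)(=O)c2ccc(C)cc2)c2ccccc12` gives 39.5% in a functional assay on 3T3-L1 cells (Mus musculus) for inhibition, with a stated time of 20 min, tested at 20 uM (a higher number here means more inhibition at the concentration tested (going by the name of the read-out), a lower number less inhibition), the highest of the three numbers. Compound 2 `Cc1ccc(S(=O)(=O)N(Cc2cn(Cc3ccc(F)cc3)nn2)Cc2c(-c3ccccc3)c3ccccc3n2S(=O)(=O)c2ccc(C)cc2)cc1` gives -7.6% in this assay, and compound 3 `Cc1ccc(S(=O)(=O)N(Cc2cn(Cc3cc(F)ccc3F)nn2)Cc2cn(S(=O)(=O)c3ccccc3)c3ccccc23)cc1` gives -6.5%, both far beyond the scatter below compound 1. Both of these compounds with the lower numbers carry a (4-methylphenyl)sulfonyl on the amine nitrogen, where compound 1 carries an acetyl.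

Compound 4 `Cc1ccc(S(=O)(=O)N(Cc2cn(Cc3cccc(F)c3F)nn2)Cc2cn(S(=O)(=O)c3ccc(C)cc3)c3ccccc23)cc1` is not yet measured. It differs from compound 1 in one place: (4-methylphenyl)sulfonyl in place of acetyl on an amine nitrogen. Among the compounds with values here, no step between two measured compounds covers exactly this change, but compound 4 comes to resemble compounds 2 and 3 in that respect, and those two show values near zero. A drop beyond the scatter is therefore expected in this assay, and compound 4 is expected to land near the two compounds with the lower numbers, at an estimated 5%, within -15% to 30%. The expected step of a number 34.5 percentage points lower from compound 1 to compound 4 (beyond the scatter) is thus a loss of most of the inhibition seen for compound 1.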

Compound 4, a percentage reported as inhibition, at one concentration (the size of the read-out at that concentration, not a potency): 71.5%
Estimate against measurement, compound 4: 66.5 percentage points below, and the stated range ends below it.
By their numbers in this assay, from the lowest: compounds 2 and 3 (each within the scatter of the next); then compound 1; then compound 4.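

In this assay, within the data shown here, putting (4-methylphenyl)sulfonyl in place of acetyl on the amine nitrogen gives a number 32 percentage points higher from compound 1 to compound 4 (beyond the scatter) and so shows, in the one pair that isolates this change, that the larger group goes with more inhibition rather than less. Compound 2 and compound 3 carry the same kind of group on that nitrogen but differ from compound 4 in other places too, so their low numbers cannot be laid on the sulfonyl group alone. Nothing at hand accounts for the gain.

From the compounds shown here alone, whether the gain follows the sulfonyl link or the methylphenyl ring stays open, and a methanesulfonyl or a benzoyl on the same nitrogen would separate the two. The read-out also comes from one concentration, so the step says nothing about potency.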